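A few compounds are considered here, and "the series" means these few. Any claim that something is new, unique, unknown or untested is made for them only; others in the source may bear on it.

Measured so far:
- compound 1, `O[C@H](COc1ccc(C(F)(F)F)cc1)CN1CCN(c2ccccc2F)CC1`: 48.9%
- compound 2, `O[C@@H](COc1ccc(C(F)(F)F)cc1)CN1CCN(c2ccc(F)cc2)CC1`: 53.7%
- compound 3, `O[C@@H](COc1ccc(Cl)cc1)CN1CCN(c2ccccc2F)CC1`: 46.9%

In an assay on HEK293 cells for inhibition of Voltage-dependent T-type calcium channel subunit alpha-1G (Homo sapiens), read by patch clamp, tested at 10 uM (on this read-out lower numbers stand for less inhibition and higher numbers for more inhibition at the one concentration tested (going by the name of the read-out)), compound 3 gives 46.9%. Of the three numbers this is the lowest as written, yet its gap to compound 1, the nearest, and its gap to compound 2, the furthest, both fall within the usual scatter of this assay, so the three compounds cannot be told apart on these data. In this assay compound 1 gives 48.9% and compound 2 gives 53.7%; both carry a trifluoromethyl group where compound 3 carries chloro.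

Compound 4, `O[C@@H](COc1ccc(C(F)(F)F)cc1)CN1CCN(c2ccccc2F)CC1`, has not yet been measured. It differs from compound 3 in one place: trifluoromethyl in place of chloro on an aromatic carbon. For the measured compounds named here, no step between measured compounds is recorded for this change, but the numbers of compound 1 and compound 2, which both bear the entering trifluoromethyl group, sit within the scatter of compound 3. The step from compound 3 to compound 4 is therefore expected to be a number 3.1 percentage points higher from compound 3 to compound 4 (within the scatter), none beyond the scatter in either direction. Compound 4 is estimated to give 50% in this assay, in a range from 35% to 65%.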

Compound 4, a percentage reported as inhibition, at one concentration (the size of the read-out at that concentration, not a potency): 50.2%
Compound 4: the middle estimate sits 0.2 percentage points below what was measured; the range from low to high includes it.
By their numbers in this assay, from the lowest: compounds 3, 1, 4 and 2 (each within the scatter of the next).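

In this assay, trifluoromethyl in place of chloro on an aromatic carbon, para to a large group, gives a number 3.3 percentage points higher from compound 3 to compound 4 (within the scatter), so this direct comparison does not separate the two groups. Likewise, 2-fluorophenyl in place of 4-fluorophenyl on an amine nitrogen in a ring gives a number 3.5 percentage points lower from compound 2 to compound 4 (within the scatter), which does not separate those two groups either. The stereocentre at the saturated chain carbon can now be read on its own, and the step of a number 1.3 percentage points higher from compound 1 to compound 4 (within the scatter) does not separate the two configurations, a clean comparison given: the fact that compounds 1 and 4 differ only in the configuration as drawn

As far as these compounds go, whether a methoxy group, a nitrile or an amine at that aromatic carbon would give a step beyond the scatter remains open. The compounds shown also leave open what a longer chain in place of the hydroxyl-bearing chain would do, and how any of these compounds would compare as a potency rather than at one concentration.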